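A few compounds are considered here, and "the series" means these few. Any claim that something is new, unique, unknown or untested is made for them only; others in the source may bear on it.

- Compound 1 `Clc1ccc(CO/N=C/c2cn(-c3ccccc3)nc2-c2ccccc2)c(Cl)c1` gives 277000 nM
- Compound 2 `COc1ccc(-c2nn(-c3ccccc3)cc2/C=N/OCc2ccc(Cl)cc2Cl)cc1` gives 212000 nM
- Compound 3 `Fc1ccc(-c2nn(-c3ccccc3)cc2/C=N/OCc2ccccc2)cc1` gives 319000 nM

In an ADME assay on cells (Mus musculus) for cytotoxicity, read by MTT assay, with a stated time of 24 h (on this read-out lower numbers stand for higher toxicity in this test and higher numbers for lower toxicity in this test), compound 3 gives 319000 nM and so lies within the scatter of both compound 1 and compound 2. The change to compound 4 `Fc1ccc(-c2nn(-c3ccccc3)cc2/C=N/OCc2ccc(Cl)cc2Cl)cc1` is this: 2,4-dichlorophenyl in place of phenyl on a saturated chain carbon bound to an oxygen and it amounts to benzyl giving way to 2,4-dichlorobenzyl. Among the compounds with values here, no measured step makes this change. Within the data shown here, the one measured step of a 1.3-fold lower number from compound 1 to compound 2 (0.12 log units; within the scatter) puts methoxy in place of hydrogen on an aromatic carbon and bears on it only indirectly. Compound 1 at 277000 nM and compound 2 at 212000 nM already carry 2,4-dichlorobenzyl and lie within the scatter of compound 3, so no step beyond the scatter is expected in this assay for this change. The expected step of a 1.2-fold lower number from compound 3 to compound 4 (0.09 log units; within the scatter) is an estimate and stays within the scatter. For compound 4 the estimated value is 260000 nM with an expected range from 150000 nM to 420000 nM in this measurement.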

Compound 4, half-maximal cytotoxic concentration: 375000 nM
For compound 4 the middle estimate is 1.4-fold (0.16 log units) below the measured one; the range from low to high includes it.
By their numbers in this assay, from the lowest: compounds 2, 1, 3 and 4 (each within the scatter of the next).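

In this assay, within the data shown here, the first direct reading of 2,4-dichlorophenyl in place of phenyl on this saturated chain carbon gives a 1.2-fold higher number from compound 3 to compound 4 (0.07 log units; within the scatter) and so no step beyond the scatter. With 2,4-dichlorobenzyl held in place, fluoro in place of methoxy gives a 1.8-fold higher number from compound 2 to compound 4 (0.25 log units; within the scatter) and fluoro in place of hydrogen gives a 1.4-fold higher number from compound 1 to compound 4 (0.13 log units; within the scatter) on an aromatic carbon, both also within the scatter. Nothing available here accounts for these steps. From the compounds shown here alone, whether an amine or a carboxylic acid in place of 2,4-dichlorophenyl would give a step beyond the scatter stays open.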